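The compounds below may be only part of what the source reports. "The series", "measured", "known", "first", "only" and "open" are said of these compounds alone.

In a functional assay on HT-29 cells (Homo sapiens) for cytotoxicity, read by MTT assay, with a stated time of 24 h, tested at 6.4 ug/mL (on this read-out lower numbers stand for a weaker effect and higher numbers for a stronger effect at the one concentration tested), compound 1 `Cn1cnnc1SCC(=O)Nc1ccc(-c2nc(-c3ccccc3)c(-c3ccccc3)n2C)cc1` gives 43.1%, and compound 2 `Cn1ccnc1SCC(=O)Nc1ccc(-c2nc(-c3ccccc3)c(-c3ccccc3)n2C)cc1` gives 30.7%. Compound 2 therefore holds the lower of the two numbers, its nearest neighbour being compound 1. For the measured compounds named here, the one measured step, a number 12.4 percentage points lower from compound 1 to compound 2 (beyond the scatter), was a modest drop. Compound 3 `Cn1c(-c2ccc(NC(=O)CN3CCN(c4ccccc4)CC3)cc2)nc(-c2ccccc2)c1-c1ccccc1` differs from compound 2 by 4-phenylpiperazin-1-yl in place of (1-methyl-1H-imidazol-2-yl)sulfanyl on a saturated chain carbon bound to a carbonyl carbon. That measured step only exchanged the group on the sulfur, so it bears little on this larger exchange, and the change from compound 2 to compound 3 is expected to bring no step beyond the scatter, a number 4.3 percentage points higher from compound 2 to compound 3 (within the scatter). In this assay compound 3 is expected to give 35%, with a range from 15% to 60%.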

Compound 3, a percentage reported as activity, at one concentration (the size of the read-out at that concentration, not a potency): 46.5%
Compound 3: middle estimate off by 11.5 percentage points, on the low side, and the stated range covers the measured number.
By their numbers in this assay, from the lowest: compound 2; then compounds 1 and 3 (each within the scatter of the next).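

At this place, on a saturated chain carbon bound to a carbonyl carbon, the sulfur link proves dispensable in this assay: 4-phenylpiperazin-1-yl replaces (1-methyl-1H-imidazol-2-yl)sulfanyl with a number 15.8 percentage points higher from compound 2 to compound 3 (beyond the scatter), and replaces (4-methyl-4H-1,2,4-triazol-3-yl)sulfanyl with a number 3.4 percentage points higher from compound 1 to compound 3 (within the scatter). A group entirely without sulfur therefore matches the triazole compound on this read-out. Nothing available here explains these numbers. From the compounds shown here alone, it remains open whether the phenyl ring of the piperazine contributes, and how a 4-methylpiperazin-1-yl or a morpholin-4-yl group would read at this place.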